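Swapping the ring-nitrogen substituent of a benzamide thiocarbamate

The compounds below may be only part of what the source reports. "The series", "measured", "known", "first", "only" and "open" are said of these compounds alone.

Measured compounds:
compound 1, `Nc1ccccc1NC(=O)c1ccc(CSC(=S)N2CCN(Cc3ccccn3)CC2)cc1`: 82.4%
compound 2, `Nc1ccccc1NC(=O)c1ccc(CSC(=S)N2CCN(C(c3ccccc3)c3ccccc3)CC2)cc1`: 8.4%

In a functional assay on A-375 cells (Homo sapiens) for antiproliferative activity, read by CCK-8 assay, with a stated time of 72 h, tested at 8 uM (a lower number here means a weaker effect, a higher number a stronger effect of the compound at the concentration tested), compound 1 gives 82.4%. Of the two numbers available it stands highest; its nearest neighbour is compound 2, whose value in this assay is 8.4%, a number lower by a margin well beyond the usual scatter. Going by the values given here, no direct step between these two compounds has been worked out, so only their two values can be set side by side.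

Compound 3, `Nc1ccccc1NC(=O)c1ccc(CSC(=S)N2CCN(c3ccc(Cl)cc3)CC2)cc1`, has not yet been measured in this assay. It differs from compound 1 in one place: 4-chlorophenyl in place of (pyridin-2-yl)methyl on an amine nitrogen in a ring. Among the compounds with values here, nothing measured so far covers this particular exchange, so the expectation rests on compound 1 alone and on the wide spread seen between compound 1 and compound 2. A downward step is expected, a number 42.4 percentage points lower from compound 1 to compound 3 (beyond the scatter), of a size that is clearly beyond the scatter but uncertain. For compound 3 the expected value in this assay is 40%, within a range from 8% to 80%.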

Compound 3, a percentage reported as inhibition, at one concentration (the size of the read-out at that concentration, not a potency): 29%
Beside the measured number, compound 3's estimate is 11 percentage points above it, and the stated range covers the measured number.
By their numbers in this assay, from the lowest: compound 2; then compound 3; then compound 1.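

In this assay, going by these compounds alone, the exchange of (pyridin-2-yl)methyl for 4-chlorophenyl on the amine nitrogen in the ring gives a large step, a number 53.4 percentage points lower from compound 1 to compound 3 (beyond the scatter), and this is the first exchange at this position that can be read directly. It shows that this position is sensitive even to a swap between two groups of equal heavy-atom count, each carrying one six-membered aromatic ring. Nothing measured here accounts for the drop.

The change removes the ring nitrogen and the linking methyl carbon and adds the chlorine all at once, and the compounds shown do not separate these parts. As far as these compounds go, how a benzyl group, or a pyridin-2-yl ring bonded directly to that same nitrogen, would read at this position remains open.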